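The source may report more compounds than this note shows. Statements on the series, on what has been measured and on what is new or still open speak of the compounds shown alone.

Measured compounds in an assay on membranes from CHO cells for displacement of a labelled ligand from adenosine receptor A1 (Homo sapiens), read by scintillation counting, with a stated time of 60 min, tested at 1 uM; on this read-out lower numbers stand for less inhibition and higher numbers for more inhibition at the one concentration tested (going by the name of the read-out):
- compound 1, `CC1=C(C(=O)OC(C)(C)C)C(c2cccs2)NC(=O)N1`: 26%
- compound 2, `CC1=C(C(=O)OCC(C)C)C(c2ccsc2)NC(=S)N1`: 8%
- compound 3, `COC(=O)C1=C(C)N(C)C(=O)NC1c1ccco1`: 45%

Compound 3 stands highest of the three numbers. Its nearest neighbour is compound 1, whose value lies lower by a gap beyond the scatter, and compound 2 lies furthest, lower again by a gap beyond the scatter. For the measured compounds named here, no pair among the three differs in one place only, so none of these gaps can be read as the effect of a single change.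

Compound 4, `CC1=C(C(=O)OCC(C)C)C(c2ccco2)NC(=O)N1C`, is not yet measured. It differs from compound 3 in one place: isopropyl in place of hydrogen on a saturated chain carbon bound to an oxygen next to a carbonyl group. The change sits on the ester chain of the shared core; the rest of compound 3 is kept.

Going by the values given here, with no single-change step on record, the size of the step in this assay can only be guessed from the three values. Compound 1 and compound 2, both carrying a larger ester chain than compound 3, give lower numbers, but they differ from compound 3 in several other places as well, so this is not a pattern that can be claimed. A small step downward, or none beyond the scatter, is expected. Compound 4 is estimated at 33%, with a range from 10% to 58%, which corresponds to an expected step of a number 12 percentage points lower from compound 3 to compound 4 (beyond the scatter).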

Compound 4, a percentage reported as inhibition, at one concentration (the size of the read-out at that concentration, not a potency): 13%
For compound 4 the middle estimate is 20 percentage points above the measured one; measured number inside the range.
By their numbers in this assay, from the lowest: compounds 2 and 4 (each within the scatter of the next); then compound 1; then compound 3.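

In this assay the ester chain of the shared core now proves to be a place where a single change has a large effect: a number 32 percentage points lower from compound 3 to compound 4 (beyond the scatter) when methoxycarbonyl becomes isobutoxycarbonyl, with the rest of compound 3 kept. For the compounds shown here, the earlier compounds could not show this, since no pair among them differed in one place only, and their larger ester chains came with other differences; this step is the first reading that belongs to the ester chain alone. No measurement on record offers an explanation for the size of this step.

The two ends of this step leave open whether the number falls gradually as the chain grows or drops only with the branched isobutyl end, and an ethyl ester, a propyl ester or a longer straight chain would separate these readings. Also open, going by these compounds, are how a carboxylic acid or an amide at this place would read, and whether isopropyl in place of hydrogen at this carbon gives a step of similar size when other parts of the shared core differ.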